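Trading a Long Side Chain for Propyl on the Core

The source may hold more compounds than are shown below. What is called first, only, known or untested is meant among the compounds shown, and "the series" means these compounds.

Compound 1 `CCCC1=C(N2CC2)C(=O)C(C(COC(N)=O)OC)=C(N2CC2)C1=O` is tested in a functional assay on L1210 cells (Mus musculus), with a stated time of 12 days (on this read-out lower numbers stand for lower potency and higher numbers for higher potency (the scale is a negative logarithm)), where compound 1 gives 5.63, the lowest of the two numbers at hand. For the measured compounds named here, its only measured companion, compound 2 `CCC1=C(N2CC2)C(=O)C(C(COC(N)=O)OC)=C(N2CC2)C1=O`, gives 6.16 in this assay, and the single known step is a number 0.53 log units higher from compound 1 to compound 2 (beyond the scatter), arising from hydrogen in place of methyl on a saturated chain carbon, two bonds along the chain from a double-bonded ring carbon. Compound 3 `CCCC1=C(N2CC2)C(=O)C(CCC)=C(N2CC2)C1=O` has not been measured. It differs from compound 1 by a group of 3 heavy atoms (3 carbon; no ring) in place of a group of 8 heavy atoms (4 carbon, 1 nitrogen, 3 oxygen; no ring), on a double-bonded ring carbon. Going by the values given here, no measured step matches this kind of change: the step from compound 1 to compound 2 alters a different substituent of the shared core, so it cannot guide the expectation here. The expected step is therefore a number 0.07 log units higher from compound 1 to compound 3 (within the scatter), meaning no change beyond the scatter, with a wide range. Compound 3 is expected to give 5.7, between 5 and 6.5.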

Compound 3, logarithm of the reciprocal of the active concentration, log(1/C): 4.92
For compound 3 the middle estimate is 0.78 log units above the measured one; measured number outside the range, below it.
By their numbers in this assay, from the lowest: compound 3; then compound 1; then compound 2.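

In this assay, the step of a number 0.71 log units lower from compound 1 to compound 3 (beyond the scatter) shows that this double-bonded ring carbon is sensitive to what it carries: propyl here does not stand in for the long side chain, which has 1 hydrogen-bond donor and 3 hydrogen-bond acceptors. This step is modest in size, like the step of a number 0.53 log units higher from compound 1 to compound 2 (beyond the scatter) at the other substituent, but it runs the opposite way, so both positions on the shared core can shift the number. No measurement here explains why the side chain gives the higher number.

Which part of the long side chain matters remains open, since only the whole chain is exchanged. It is also unclear how a shorter chain ending in an amine or a carboxylic acid would compare at this position.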